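The source may report more compounds than this note shows. Statements on the series, on what has been measured and on what is new or still open speak of the compounds shown alone.

Measured compounds:
- Compound 1 `O=C1c2ccccc2CN1c1cnc(NCc2c(F)ccc3c2CCO3)n2cnnc12`: 4000 nM
- Compound 2 `Cc1nc(CO)ccc1-c1cnc(NCc2c(F)ccc3c2CCO3)c2cn[nH]c(=O)c12`: 3000 nM
- Compound 3 `Cc1ncccc1-c1cnc(NCc2c(F)ccc3c2CCO3)c2n[nH]c(=O)n12`: a limit of the assay, < 2000 nM

In a physicochemical assay for solubility, read by LC-MS, in phosphate buffer, with a stated time of 24 h, at pH 7.4 (on this read-out higher numbers stand for higher solubility and lower numbers for lower solubility), compound 1 gives 4000 nM and stands highest of the two numbers shown, while compound 2 gives 3000 nM, a difference that lies within the scatter of repeated measurements, so the two cannot be placed in order. For compound 3 the assay returns only a limit, < 2000 nM, as noted in the limit of < 2000 nM in this assay, at which 1 of the 3 values shown sits. Among the compounds with values here, no pair among the measured compounds differs in a single place, so no measured step is available to guide the next change.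

Compound 4 `O=C(Nc1cnc(NCc2c(F)ccc3c2CCO3)n2cnnc12)c1ccccc1` differs from compound 1 in one place: a group of 9 heavy atoms (7 carbon, 1 nitrogen, 1 oxygen; one six-membered aromatic ring of carbon only) in place of a group of 10 heavy atoms (8 carbon, 1 nitrogen, 1 oxygen; one five-membered non-aromatic ring with 1 hetero atom, one six-membered aromatic ring of carbon only), on an aromatic carbon. The change keeps the same shared core and exchanges one amide-bearing group for another of nearly the same size. Within the data shown here, with no measured step to lean on, the step from compound 1 to compound 4 is expected to be small, no change at the digits printed from compound 1 to compound 4 (within the scatter), and not beyond the scatter. Compound 4 is therefore estimated at 4000 nM in this assay, with a range from 1500 nM to 10000 nM.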

Compound 4, solubility: 2000 nM
Compound 4: middle estimate off by 2.0-fold (0.30 log units), on the high side; measured number inside the range.
By their numbers in this assay, from the lowest: compounds 4, 2 and 1 (each within the scatter of the next).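

At this aromatic carbon of the shared core, benzamido in place of the group carried by compound 1 gives, in this assay, a 2.0-fold lower number from compound 1 to compound 4 (0.30 log units; within the scatter). Within the data shown here, this is the first measured step at a single place, and it shows that exchanging the group that leaves for benzamido, which brings the amide hydrogen and has one ring fewer, yields two compounds that this read-out cannot tell apart. Compound 3 differs from both in more than one place and gives only a limit of the assay, not a number: the limit of < 2000 nM in this assay, at which 1 of the 4 values shown sits.

On these data alone, it remains open whether an amine such as morpholine, or a carboxylic acid, on this aromatic carbon would give a step beyond the scatter. Also open, as far as these compounds go, is whether the N-methyl form of the benzamido group, without the amide hydrogen, would read any differently.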